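Replacing a benzyloxy group on the core with methylcarbamoyl

The source may report more compounds than this note shows. Statements on the series, on what has been measured and on what is new or still open speak of the compounds shown alone.

Measured so far:
compound 1 `CCCCNc1nc(N)nc2cccc(C)c12`: 0.3 uM
compound 2 `CCCCNc1nc(N)nc2cccc(CCc3ccccc3)c12`: 0.47 uM
compound 3 `CCCCNc1nc(N)nc2cccc(OCc3ccccc3)c12`: 1.66 uM

In an ADME assay on HEK293 cells for agonist activity at Toll-like receptor 8 (Homo sapiens), read by a luciferase reporter, with a stated time of 6 h (a higher number here means that more compound is needed for the effect, a lower number that less compound is needed), compound 3 gives the highest of the three numbers, set apart from compound 2 by a 3.5-fold higher number from compound 2 to compound 3 (0.55 log units; beyond the scatter) and from compound 1 by a 5.5-fold higher number from compound 1 to compound 3 (0.74 log units; beyond the scatter). Compound 4 `CCCCNc1nc(N)nc2cccc(C(=O)NC)c12` differs from compound 3 in one place: methylcarbamoyl in place of benzyloxy on an aromatic carbon. Among the measured compounds shown here, no measured step puts methylcarbamoyl on this aromatic carbon, so only the two steps that introduce benzyloxy bear on it, both modest and both leading to higher numbers. Going by these compounds, removing benzyloxy may therefore return the number toward the range of compounds 1 and 2, but the incoming group is untested, so the expectation is wide. Compound 4 is estimated at 0.6 uM in this assay, with a range of 0.15 uM to 3 uM, which would mean a step of a 2.8-fold lower number from compound 3 to compound 4 (0.44 log units; beyond the scatter).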

Compound 4, minimum effective concentration: 0.39 uM
Compound 4: the middle estimate sits 1.5-fold (0.19 log units) above what was measured; the measured number falls inside the stated range.
By their numbers in this assay, from the lowest: compounds 1, 4 and 2 (each within the scatter of the next); then compound 3.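

On this aromatic carbon, methylcarbamoyl in place of benzyloxy brings the number back down (step: a 4.3-fold lower number from compound 3 to compound 4 (0.63 log units; beyond the scatter)). Methylcarbamoyl is not separated from either of the other two groups (steps: a 1.2-fold lower number from compound 2 to compound 4 (0.08 log units; within the scatter); a 1.3-fold higher number from compound 1 to compound 4 (0.11 log units; within the scatter)), so among these four compounds only benzyloxy stands apart. Nothing available explains why benzyloxy alone differs.

Going by these compounds, it remains open whether a carboxylic acid, an amine or a longer chain on this carbon would group with compound 1, compound 2 and compound 4 or with compound 3. On these data alone, it also remains open whether dimethylcarbamoyl, which lacks the amide hydrogen, would match methylcarbamoyl.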